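The compounds below may be only part of what the source reports. "The series", "measured", "known", "first", "only" and "open" are said of these compounds alone.

Going by the values given here, in an ADME assay on microsomes from liver (Mus musculus, strain CD1) for metabolic stability, read by LC-MS, using NADPH, with a stated time of 30 min, tested at 3 uM (on this read-out higher numbers stand for a more stable compound and lower numbers for a less stable compound), three related compounds have numbers so far. Compound 1 `CN1Cc2cc(-c3ccc(-c4cncc(NS(=O)(=O)c5ccc(F)cc5F)c4)s3)cnc2C1=O` gives 100%, and compound 2 `COc1ncc(-c2ccc(-c3cnc4c(c3)CN(C)C4=O)s2)cc1NS(=O)(=O)c1ccc(F)cc1F` gives 100%. Compound 3 `CN1Cc2cc(-c3ccc(-c4cncc(NS(=O)(=O)c5cccc(C(F)(F)F)c5)c4)s3)cnc2C1=O` gives 88%, the lowest of the three, though still a high number on this scale.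

The next compound, compound 4 `CN1Cc2cc(-c3ccc(-c4cncc(NS(=O)(=O)c5ccccc5C(F)(F)F)c4)s3)cnc2C1=O`, has the same atoms as compound 3, joined differently. On the sulfonyl sulfur, 2-(trifluoromethyl)phenyl stands in place of 3-(trifluoromethyl)phenyl (2-(trifluoromethyl)phenyl in place of 3-(trifluoromethyl)phenyl on a sulfonyl sulfur).

Two measured steps can be weighed against this change. The more relevant one alters the same place: a number 12 percentage points lower from compound 1 to compound 3 (beyond the scatter), a modest step beyond the scatter, with 3-(trifluoromethyl)phenyl in place of 2,4-difluorophenyl. The other, no change at the digits printed from compound 1 to compound 2 (within the scatter), puts methoxy in place of hydrogen on an aromatic carbon. It is a different kind of change and offers little guidance here.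

Among the compounds with values here, no measured compound carries the 2-(trifluoromethyl)phenyl group, so the data do not settle the direction. Within the data shown here, with the modest size of a number 12 percentage points lower from compound 1 to compound 3 (beyond the scatter) as the only guide at this place, a small change is expected. The expected step is no change at the digits printed from compound 3 to compound 4 (within the scatter), and it may not rise beyond the scatter. For compound 4 the estimated value in this assay is 88%, with an expected range of 72% to 100%.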

Compound 4, percent of the compound remaining in the Mus musculus assay: 86%
Beside the measured number, compound 4's estimate is 2 percentage points above it; the range from low to high includes it.
By their numbers in the Mus musculus assay, from the lowest: compounds 4 and 3 (each within the scatter of the next); then compounds 1 and 2 (each within the scatter of the next).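

Moving the trifluoromethyl group around the phenyl ring on the sulfonyl sulfur, with the atoms otherwise unchanged, gives a number 2 percentage points lower from compound 3 to compound 4 (within the scatter) in the Mus musculus assay, so this read-out does not distinguish these two arrangements. Against the 2,4-difluorophenyl group of compound 1, both trifluoromethyl-bearing compounds sit beyond the scatter, with a number 12 percentage points lower from compound 1 to compound 3 (beyond the scatter) and a number 14 percentage points lower from compound 1 to compound 4 (beyond the scatter), so among these compounds the difference from compound 1 holds for both arrangements of the group. The same rearrangement that leaves stability unresolved does separate the two compounds in a physicochemical assay for solubility, read by HPLC (on this read-out higher numbers stand for higher solubility and lower numbers for lower solubility), where compound 3 gives 20300 ug/mL and compound 4 gives 4280 ug/mL and which shows that a change invisible in one read-out can still register in another: the measured solubility of compound 3, 20300 ug/mL, and of compound 4, 4280 ug/mL, a 4.7-fold lower number (0.68 log units; beyond the scatter)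

What these compounds leave open is how far the stability at this position depends on the aryl group at all, for instance whether a plain phenyl or a small methyl group on the sulfonyl sulfur would fall nearer compound 1 or nearer compounds 3 and 4. As far as these compounds go, it is also open whether the methoxy group of compound 2 would leave the numbers unchanged when paired with either trifluoromethyl-bearing phenyl group.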